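The source may hold more compounds than are shown below. What is called first, only, known or untested is meant among the compounds shown, and "the series" means these compounds.

Measured compounds:
compound 1, `Cc1ccc(C2=NN(C(=S)Nc3ccccc3)C(c3ccc4c(c3)OCCO4)C2)cc1`, 6320 nM
compound 2, `FC(F)(F)c1ccc(C2=NN(C(=S)Nc3ccccc3)C(c3ccc4c(c3)OCCO4)C2)cc1`, 43500 nM
compound 3, `O=[N+]([O-])c1ccc(C2=NN(C(=S)Nc3ccccc3)C(c3ccc4c(c3)OCCO4)C2)cc1`, 78100 nM

All three share one core and differ only in the group on the outer phenyl ring. In a functional assay on A-375 cells (Homo sapiens) for antiproliferative activity, read by MTT assay, with a stated time of 48 h (on this read-out lower numbers stand for stronger inhibition of growth and higher numbers for weaker inhibition of growth), compound 3 gives the highest number of the three: the step of a 1.8-fold higher number from compound 2 to compound 3 (0.25 log units; within the scatter) is within the scatter, so compound 2 and compound 3 cannot be told apart, while the step of a 12-fold higher number from compound 1 to compound 3 (1.09 log units; beyond the scatter) is large and clearly separates compound 3 from compound 1. Compound 4, `S=C(Nc1ccccc1)N1N=C(c2ccc(OCc3ccccc3)cc2)CC1c1ccc2c(c1)OCCO2`, is not yet measured. It differs from compound 3 in benzyloxy in place of nitro on an aromatic carbon.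

Among the measured compounds shown here, two measured steps bear on this change: a 6.9-fold higher number from compound 1 to compound 2 (0.84 log units; beyond the scatter) and a 12-fold higher number from compound 1 to compound 3 (1.09 log units; beyond the scatter). Both alter the same position. Both replaced methyl with another group and both raised the number, one modestly and one by a large margin. Benzyloxy is a different kind of group from either of these, so the measured steps give only an indirect guide. Going from nitro to benzyloxy undoes the change that raised the number in compound 3, and a return toward the level of compound 1 is the plainest expectation, though with wide uncertainty.

The expected step is an 8.7-fold lower number from compound 3 to compound 4 (0.94 log units; beyond the scatter), a lower number. Compound 4 is therefore estimated at 9000 nM, with a range from 2000 nM to 40000 nM.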

Compound 4, concentration for 50% growth inhibition: 350 nM
Compound 4: middle estimate off by 26-fold (1.41 log units), on the high side, outside the stated range (below it).
By their numbers in this assay, from the lowest: compound 4; then compound 1; then compounds 2 and 3 (each within the scatter of the next).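

In this assay, among the compounds shown here, this position proves open to a much larger group than the earlier compounds carried: benzyloxy, which brings a second six-membered aromatic ring, gives an 18-fold lower number from compound 1 to compound 4 (1.26 log units; beyond the scatter) and so goes past the level of the methyl group instead of merely returning to it. The same change gives a 120-fold lower number from compound 2 to compound 4 (2.09 log units; beyond the scatter) and a 220-fold lower number from compound 3 to compound 4 (2.35 log units; beyond the scatter) at this position, whereas the earlier compounds had shown only a rise in the number whenever methyl was replaced. Compound 4 therefore has the lowest number of the four, with its steps to all three others lying beyond the scatter, and the choice of group here spans a far wider range than the first three compounds suggested.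

The compounds shown leave open whether the ring of benzyloxy, its ether oxygen or its overall length accounts for the lower number, a question that a methoxy group, a phenyl ring or a benzylamine at this position could help to separate. No measurement given here explains the size of this change.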